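This account rests on a few compounds, and the source may have more. Where it says the series, first, only, none or still open, it means among the compounds named here.

The study tests for antiproliferative activity in an ADME assay on L02 cells (Homo sapiens) for antiproliferative activity, read by MTT assay, with a stated time of 48 h; on this read-out lower numbers stand for stronger inhibition and higher numbers for weaker inhibition. Compound 1, with the structure `N#CC1=C(N)Oc2c(c3nc4ccccc4nc3c3ccccc23)C12C(=O)N(Cc1cnnn1-c1cc(Cl)ccc1Cl)c1ccccc12`, gives only a limit of the assay in this assay, namely > 50000 nM. Compound 2, with the structure `Cc1cccc(-n2nncc2CN2C(=O)C3(C(C#N)=C(N)Oc4c(N)cc5nc6ccccc6nc5c43)c3ccccc32)c1`, likewise gives only a limit of the assay, > 50000 nM. Compound 2 therefore stands at the limit of > 50000 nM in this assay, at which 2 of the 2 values shown sit, and no number places it more precisely. Compound 3, with the structure `N#CC1=C(N)Oc2c(N)cc3nc4ccccc4nc3c2C12C(=O)N(Cc1cnnn1-c1ccc([N+](=O)[O-])cc1)c1ccccc12`, remains to be measured in this assay. It differs from compound 2 by 4-nitrophenyl in place of 3-methylphenyl on an aromatic nitrogen. Among the measured compounds shown here, no step between two measured compounds is available to gauge what such a change does, and the two values shown are both limits. For compound 3 the step of a number no higher from compound 2 to compound 3 (the limit leaves the size open) is expected to be none beyond the scatter. The value of compound 3 in this assay is estimated at 50000 nM, with a range from 20000 nM to 150000 nM, and most likely the assay will again report only a limit.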

Compound 3, half-maximal inhibitory concentration: > 50000 nM
Compound 3 gave a limit, no number (the forecaster's own chance of this, stated with the estimate: 80%); the middle value lies on the limit itself.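

No step can be read from compound 2 to compound 3, because both values are limits and not numbers: the limit of > 50000 nM in this assay, at which 3 of the 3 values shown sit.

The compounds shown leave open whether 4-nitrophenyl in place of 3-methylphenyl on the aromatic nitrogen makes any difference, and where any of the three compounds would fall on a numerical scale.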